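Halogen swap on the pendant phenyl ring of the aminothiophene ketone

The source may report more compounds than this note shows. Statements on the series, on what has been measured and on what is new or still open speak of the compounds shown alone.

Compound 3 `Nc1scc(-c2cccc(Cl)c2)c1C(=O)c1ccc(Cl)cc1` gives 58% in a functional assay on CHO cells for agonist activity at adenosine receptor A1 (Homo sapiens), read by fluorescence and ERK phosphorylation, with stated times of 30 min and 1.5 h, tested at 3 uM (on this read-out higher numbers stand for a stronger effect at the one concentration tested and lower numbers for a weaker effect), the second highest of three numbers. Compound 1 `Nc1scc(-c2ccccc2)c1C(=O)c1ccc(Cl)cc1` gives 51%, and a number 7 percentage points higher from compound 1 to compound 3 (within the scatter). Compound 2 `Nc1scc(-c2ccccc2F)c1C(=O)c1ccc(Cl)cc1` gives 70%, so that a number 12 percentage points lower from compound 2 to compound 3 (beyond the scatter); likewise a number 19 percentage points higher from compound 1 to compound 2 (beyond the scatter). Compound 4 `Nc1scc(-c2cccc(Br)c2)c1C(=O)c1ccc(Cl)cc1` differs from compound 3 in one place: bromo in place of chloro on an aromatic carbon. Among the compounds with values here, no measured step swaps one halogen for another; the nearest comparison, a number 7 percentage points higher from compound 1 to compound 3 (within the scatter), stays within the scatter, whereas a number 19 percentage points higher from compound 1 to compound 2 (beyond the scatter) lies beyond it. With so little to go on, compound 4 is expected to sit near compound 3, with no change at the digits printed from compound 3 to compound 4 (within the scatter). The estimate for compound 4 in this assay is therefore 58%, between 44% and 72%.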

Compound 4, a percentage reported as activity, at one concentration (the size of the read-out at that concentration, not a potency): 62%
For compound 4 the middle estimate is 4 percentage points below the measured one; the measured number falls inside the stated range.
By their numbers in this assay, from the lowest: compounds 1, 3, 4 and 2 (each within the scatter of the next, the first and the last beyond it).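

Bromo in place of chloro gives a number 4 percentage points higher from compound 3 to compound 4 (within the scatter), so this first swap of one halogen for another at this position does not separate the two, yet bromo in place of hydrogen gives a number 11 percentage points higher from compound 1 to compound 4 (beyond the scatter), a step that chloro did not clear. Against the 2-fluorophenyl compound, the 3-bromophenyl group gives a number 8 percentage points lower from compound 2 to compound 4 (within the scatter), whereas the 3-chlorophenyl group lay beyond the scatter. Nothing available explains these differences. The compounds shown leave open how a methoxy group, a nitrile or an amine would fare at this position. Going by these compounds, each reading also comes from a single concentration, so potency remains open.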